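From piperazine back to an arylamine: potency expected to return

The compounds below may be only part of what the source reports. "The series", "measured", "known", "first", "only" and "open" are said of these compounds alone.

Compound 1, `Cc1cc(Nc2ccc(Cl)cc2)nc(SCc2nc3ccccc3[nH]2)n1`: in a functional assay on MGC-803 cells (Homo sapiens) for cytotoxicity, read by MTT assay, with a stated time of 72 h (a lower number here means a stronger inhibitor, a higher number a weaker inhibitor), compound 1 gives 28200 nM.
Compound 2, `Cc1cc(N2CCNCC2)nc(SCc2nc3ccccc3[nH]2)n1`: in this assay compound 2 reaches a limit of the assay, > 100000 nM, rather than a number.

Compound 2 therefore stands at the weak end of what has been measured, known only through (the limit of > 100000 nM in this assay, at which 1 of the 2 values shown sits). Compound 3, `Cc1ccc(Nc2cc(C)nc(SCc3nc4ccccc4[nH]3)n2)cc1`, is the next step: (4-methylphenyl)amino in place of piperazin-1-yl on an aromatic carbon. Among the compounds with values here, the one measured step that bears on this change runs the other way, an at least 3.5-fold higher number from compound 1 to compound 2 (0.54 log units; beyond the scatter), where the compound carrying the arylamine was the stronger one. Reversing that move, with a methyl instead of a chlorine on the phenyl ring, is expected to lower the number by about an at least 3.3-fold lower number from compound 2 to compound 3 (0.52 log units; beyond the scatter) in this assay. Compound 3 is accordingly estimated at 30000 nM, with a likely range from 10000 nM to 100000 nM.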

Compound 3, half-maximal inhibitory concentration: 7390 nM
Estimate against measurement, compound 3: 4.1-fold (0.61 log units) above; the whole stated range lies above it.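

In this assay, a second arylamine now outperforms piperazin-1-yl at this position, with an at least 13-fold lower number from compound 2 to compound 3 (1.13 log units; beyond the scatter), so the advantage over piperazin-1-yl does not depend on the chlorine of compound 1. Within the data shown here, the group on the phenyl ring also matters, because methyl in place of chloro gives a 3.8-fold lower number from compound 1 to compound 3 (0.58 log units; beyond the scatter), a modest but real change that the earlier compounds could not show. Compound 2 is known only through a limit, so the full size of the step from piperazin-1-yl cannot be stated: the limit of > 100000 nM in this assay, at which 1 of the 3 values shown sits.

The compounds shown do not reveal why methyl does better than chloro here. They also leave open how a methoxy group or a fluorine on the phenyl ring would compare, and whether a phenyl ring with no added group would keep this potency.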